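This account rests on a few compounds, and the source may have more. Where it says the series, first, only, none or still open, it means among the compounds named here.

Measured so far in a toxicity assay on L02 cells (Homo sapiens) for cytotoxicity, read by MTT assay, with a stated time of 72 h; a higher number here means a weaker inhibitor, a lower number a stronger inhibitor:
compound 1 `CCCCN1CCN(CCCCn2c3c(c4ccccc42)C(=O)c2c[n+]([O-])c4ccccc4c2C3=O)CC1` gives 5690 nM
compound 2 `O=C1c2c[n+]([O-])c3ccccc3c2C(=O)c2c1c1ccccc1n2Cc1cn([C@@H]2O[C@H](CO)[C@@H](O)[C@H](O)[C@H]2O)nn1` gives 420 nM

Of these two numbers, compound 1 has the higher at 5690 nM and so is the weaker inhibitor in this assay. Compound 2 lies lower at 420 nM, and the gap between the two is beyond the scatter.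

Compound 3 `CN1CCN(CCCCCn2c3c(c4ccccc42)C(=O)c2c[n+]([O-])c4ccccc4c2C3=O)CC1` has not yet been measured. Relative to compound 1 it carries this change: (4-methylpiperazin-1-yl)methyl in place of 4-butylpiperazin-1-yl on a saturated chain carbon, four bonds along the chain from an aromatic nitrogen. The change sits on a saturated chain carbon, four bonds along the chain from an aromatic nitrogen. Cut one bond further out, the same difference reads 2-(4-butylpiperazin-1-yl)ethyl to 3-(4-methylpiperazin-1-yl)propyl.

Among the measured compounds shown here, no measured pair isolates this change, so the expectation is only loosely anchored. Compound 2 at 420 nM shows that a much lower number is reachable on the shared core, though it differs from compound 1 in more than this chain. A moderate move towards a lower number is therefore expected, and the expected size is a 2.3-fold lower number from compound 1 to compound 3 (0.36 log units; beyond the scatter). For compound 3 the estimated value is 2500 nM, with an expected range of 600 nM to 8000 nM.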

Compound 3, half-maximal inhibitory concentration: 1640 nM
Estimate against measurement, compound 3: 1.5-fold (0.18 log units) above; measured number inside the range.
By their numbers in this assay, from the lowest: compound 2; then compound 3; then compound 1.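

In this assay, putting (4-methylpiperazin-1-yl)methyl in place of 4-butylpiperazin-1-yl on a saturated chain carbon, four bonds along the chain from an aromatic nitrogen, gives a 3.5-fold lower number from compound 1 to compound 3 (0.54 log units; beyond the scatter), so this position responds to a change confined to the chain and its piperazine, with the rest of the core held constant. The step bundles two differences, butyl to methyl on the piperazine and the chain read as 2-(4-butylpiperazin-1-yl)ethyl to 3-(4-methylpiperazin-1-yl)propyl, and a single number cannot separate them. No measured property of these compounds accounts for the step.

The compounds shown leave open whether the end group or the chain length carries the step, a question that a methyl-bearing piperazine on the shorter chain, or a butyl-bearing piperazine on the longer chain, would settle. Also open, going by these compounds, is how far the trend runs in this assay, for example with an ethyl group on the piperazine, a morpholine in its place, or a longer chain such as 4-(4-methylpiperazin-1-yl)butyl.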